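The source may hold more compounds than are shown below. What is called first, only, known or untested is meant among the compounds shown, and "the series" means these compounds.

Compound 1 `Cc1cc2ccccc2nc1-c1cn(CCC(F)(F)C(F)(F)C(F)(F)C(F)(F)C(F)(F)C(F)(F)C(F)(F)C(F)(F)F)nn1` has been tested in a functional assay on THP-1 cells (Homo sapiens) for cytotoxicity, read by MTT assay, with a stated time of 24 h; on this read-out lower numbers stand for stronger inhibition and higher numbers for weaker inhibition. Compound 1 gives > 100 ug/mL, which is a limit of the assay and not a number. Among the compounds with values here, compound 2 `CCCCCCCCCCn1cc(-c2nc3ccccc3cc2CCC)nn1` is the only other compound measured so far. Compound 2 gives > 100 ug/mL, which is also a limit. The record therefore holds no exact number: the limit of > 100 ug/mL in this assay, at which 2 of the 2 values shown sit. Compound 3 `CCc1cc2ccccc2nc1-c1cn(CCC(F)(F)C(F)(F)C(F)(F)C(F)(F)C(F)(F)C(F)(F)C(F)(F)C(F)(F)F)nn1` differs from compound 1 in one place, (methyl in place of hydrogen on a saturated chain carbon bound to an aromatic carbon), with methyl in place of hydrogen on a saturated chain carbon bound to an aromatic carbon. Within the data shown here, no measured pair shows what this change does, so no step beyond the usual scatter is expected, in either direction. The estimated step is a number no higher from compound 1 to compound 3 (the limit leaves the size open), and a further limit is the likeliest report. For compound 3 the expected value is 100 ug/mL, with an estimated range from 50 ug/mL to 200 ug/mL.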

Compound 3, half-maximal inhibitory concentration: > 100 ug/mL
Compound 3 ended at the assay's limit; the forecaster's own chance of this, stated with the estimate: 85%; the middle value lies on the limit itself.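

Compound 1 and compound 3 both end at a limit and not at a number, so no step can be read between them: the limit of > 100 ug/mL in this assay, at which 3 of the 3 values shown sit. The compounds shown leave open what exact value any of them would give, and whether going from methyl to ethyl changes it at all.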